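This account rests on a few compounds, and the source may have more. Where it says the series, first, only, none or still open, it means among the compounds named here.

Measured so far:
Compound 1 `Cc1ccc(-n2nncc2CN2C(=O)C3(C(C#N)=C(N)Oc4c3c3nc5ccccc5nc3c3ccccc43)c3ccccc32)cc1C` gives > 50000 nM in a functional assay on MCF7 cells (Homo sapiens) for antiproliferative activity, read by MTT assay, with a stated time of 48 h; on this read-out higher numbers stand for weaker inhibition and lower numbers for stronger inhibition; this is a limit of the assay, not a number.
Compound 2 `CCc1ccccc1-n1nncc1CN1C(=O)C2(C(C#N)=C(N)Oc3c(N)cc4nc5ccccc5nc4c32)c2ccccc21` gives 24600 nM.
Compound 3 `COc1ccc(-n2nncc2CN2C(=O)C3(C(C#N)=C(N)Oc4c(N)cc5nc6ccccc6nc5c43)c3ccccc32)cc1` gives > 50000 nM, again only a limit.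

Compound 3 therefore stands at the floor of what the assay reports, because of the limit of > 50000 nM in this assay, at which 2 of the 3 values shown sit. Going by the values given here, the single measured step, an at least 2.0-fold higher number from compound 2 to compound 3 (0.30 log units; that floor lies within the scatter), concerns a different swap on the same aromatic nitrogen and says nothing about fluorine. The change now followed is 2,6-difluorophenyl in place of 4-methoxyphenyl on an aromatic nitrogen. Among the compounds with values here, with no measured step bearing on it, no shift beyond the scatter is expected, and the value is expected to stay near the limit. Compound 4 `N#CC1=C(N)Oc2c(N)cc3nc4ccccc4nc3c2C12C(=O)N(Cc1cnnn1-c1c(F)cccc1F)c1ccccc12` is thus estimated at 45000 nM, within 15000 nM to 100000 nM. The expected step is an at least 1.1-fold lower number from compound 3 to compound 4 (0.04 log units; that floor lies within the scatter).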

Compound 4, half-maximal inhibitory concentration: > 50000 nM
Compound 4 was reported as a limit (the forecaster's own chance of this, stated with the estimate: 70%); middle value at least 1.1-fold (0.04 log units) away from the limit.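

Compound 4 adds a second replacement for the 2-ethylphenyl group on this aromatic nitrogen, and it too reaches only a limit in this assay, so the limit now caps most of the series: the limit of > 50000 nM in this assay, at which 3 of the 4 values shown sit. The change from 2-ethylphenyl to 2,6-difluorophenyl gives an at least 2.0-fold higher number from compound 2 to compound 4 (0.30 log units; that floor lies within the scatter). The step between the two limits cannot be read, so 4-methoxyphenyl and 2,6-difluorophenyl cannot be ranked.

Still open, going by these compounds, is whether a 2-methylphenyl group or a plain methyl group at this position would give a true number rather than a limit.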